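From Chloro to Methyl: Compound 2 and Compound 4

The source may report more compounds than this note shows. Statements on the series, on what has been measured and on what is new or still open speak of the compounds shown alone.

In a physicochemical assay for lipophilicity (a higher number here means a more lipophilic compound, a lower number a more polar compound), compound 2 `CCC(=O)Oc1c(OC)c(OC)c(OC(=O)CC)c2cc(Cl)ccc12` gives 4.3, the second highest of three numbers. Compound 1 `CCC(=O)Oc1c(OC)c(OC)c(OC(=O)CC)c2ccccc12` lies lower at 3.44, and compound 3 `CCC(=O)Oc1c(Oc2ccccc2)c(Oc2ccccc2)c(OC(=O)CC)c2cc(Cl)ccc12` lies higher at 6.6.

The next compound, compound 4 `CCC(=O)Oc1c(OC)c(OC)c(OC(=O)CC)c2cc(C)ccc12`, keeps the shared core of compound 2 and has methyl in place of chloro on an aromatic carbon.

For the measured compounds named here, one measured step bears on this carbon: chloro in place of hydrogen, which gave a number 0.86 log units higher from compound 1 to compound 2 (beyond the scatter). Going by the values given here, no measured compound carries methyl there, so no step gives the size of the change directly. Compound 3 differs from compound 2 elsewhere in the molecule and offers no guide to a change at this carbon.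

With that single step as the only reference, compound 4 is expected to keep most of the rise seen in a number 0.86 log units higher from compound 1 to compound 2 (beyond the scatter) and to stay nearer to compound 2 than to compound 1. The expected shift in this assay is small and downward, an estimated a number 0.20 log units lower from compound 2 to compound 4 (within the scatter), and it may well not exceed the scatter. For compound 4 the estimate is 4.1, with an expected range from 3.75 to 4.45.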

Compound 4, partition coefficient: 3.9
Estimate against measurement, compound 4: 0.20 log units above; the range from low to high includes it.
By their numbers in this assay, from the lowest: compound 1; then compound 4; then compound 2; then compound 3.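

In this assay, this carbon now has a direct comparison between two substituents, and the choice between them matters: the change to methyl gave a number 0.40 log units lower from compound 2 to compound 4 (beyond the scatter), so chloro and methyl cannot be treated as interchangeable here. Methyl in place of hydrogen also counts as a real step, at a number 0.46 log units higher from compound 1 to compound 4 (beyond the scatter), so both substituents give a number above that of the unsubstituted compound, with the step for methyl smaller than a number 0.86 log units higher from compound 1 to compound 2 (beyond the scatter). Nothing available explains why the two groups differ at this carbon.

With only hydrogen, chloro and methyl shown at this carbon, the compounds leave open whether the order among them says anything about other groups, such as an amine, a carboxylic acid or a longer chain, and how far such groups would move the number in either direction. They also leave open whether methyl in place of chloro would give a step of similar size on the core of compound 3, where the rest of the molecule differs and the number is much higher.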